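The compounds below may be only part of what the source reports. "The series", "measured", "known", "first", "only" and "open" are said of these compounds alone.

Compound 1 `COc1c(OCc2nc3ccccc3[nH]2)cc(O)c2c(=O)cc(-c3ccccc3)oc12` sits at the edge of what can be read in a functional assay on A549 cells (Homo sapiens) for cytotoxicity, read by MTT assay, with a stated time of 48 h; a higher number here means a weaker inhibitor, a lower number a stronger inhibitor. In this assay compound 1 gives > 100000 nM, which is a limit and not a number. The two related compounds add no reading. For compound 2 `CC(CO)NCCOc1c(O)cc(O)c2c(=O)cc(-c3ccccc3)oc12` the entry is "not determined" (no result reported). For compound 3 `CNCCOc1c(O)cc(O)c2c(=O)cc(-c3ccccc3)oc12` the entry is "not determined" (no result reported). Among the measured compounds shown here, no measured step therefore shows how far a change on this chain can move the result.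

Compound 4 `COc1c(OCCCN2CCN(C)CC2)cc(O)c2c(=O)cc(-c3ccccc3)oc12` is the next to be tested. Its difference from compound 1 is 2-(4-methylpiperazin-1-yl)ethyl in place of 1H-benzimidazol-2-yl on a saturated chain carbon bound to an oxygen on an aromatic ring. Cut one bond further out, the change reads (1H-benzimidazol-2-yl)methyl to 3-(4-methylpiperazin-1-yl)propyl.

For the measured compounds named here, the only anchor is compound 1, with the limit of > 100000 nM in this assay, at which 1 of the 3 values shown sits, so a numerical result could only fall on the stronger side of it. A moderate gain in inhibition is expected, though a second limit remains possible. The expected change is an at least 2.5-fold lower number from compound 1 to compound 4 (0.39 log units; beyond the scatter), and its size is uncertain. Compound 4 is estimated at 40000 nM, with an expected range from 12000 nM to 100000 nM.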

Compound 4, half-maximal inhibitory concentration: 9900 nM
Compound 4: middle estimate off by 4.0-fold (0.61 log units), on the high side; measured number below the stated range.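

Among the compounds shown here, compound 4 gives the first single number, which shows that a compound with this core and a group at this oxygen-bound chain can produce a reading in this assay. Replacing the (1H-benzimidazol-2-yl)methyl with 3-(4-methylpiperazin-1-yl)propyl gives an at least 10-fold lower number from compound 1 to compound 4 (1.00 log units; beyond the scatter), so a change at this position can move the result beyond the scatter. The value of compound 1 is a limit and not a number, so the full size of this step remains unknown: the limit of > 100000 nM in this assay, at which 1 of the 4 values shown sits.

The change replaces the aromatic rings and lengthens the chain together, so the compounds shown cannot separate the contribution of the 4-methylpiperazin-1-yl ring from that of the chain. For the compounds shown here, how a morpholine ring or a simple dimethylamino group on the same propyl chain would read remains open, and compound 2 and compound 3 provide no steps that can be read.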